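The source may hold more compounds than are shown below. What is called first, only, known or untested is meant among the compounds shown, and "the series" means these compounds.

Of the compounds shown here, three have so far been measured in an ADME assay on cells (Hepatocyte, Mus musculus) for metabolic stability; on this read-out lower numbers stand for a shorter-lived compound and higher numbers for a longer-lived compound.
Compound 1, `O=C(OC1CCC(CN2CCN(c3cc(=O)c4cc(C(F)(F)F)cc([N+](=O)[O-])c4s3)CC2)CC1)c1ccccc1`, gives 0.903 h.
Compound 2, `O=c1cc(N2CCN(CC3CCC(NS(=O)(=O)c4ccccc4)CC3)CC2)sc2c([N+](=O)[O-])cc(C(F)(F)F)cc12`, reaches only a limit of the assay, > 1.55 h.
Compound 3, `Cc1ccc(C(=O)OC2CCC(CN3CCN(c4cc(=O)c5cc(C(F)(F)F)cc([N+](=O)[O-])c5s4)CC3)CC2)cc1`, gives 0.202 h.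

Compound 2 therefore stands at the limit of > 1.55 h in this assay, at which 1 of the 3 values shown sits; its true number is not known, only that it lies past that limit. Among the compounds with values here, two measured steps touch it. The step of an at least 1.7-fold higher number from compound 1 to compound 2 (0.23 log units; that floor lies within the scatter) came with (phenylsulfonyl)amino in place of benzoyloxy on a saturated ring carbon. The step of an at least 7.6-fold lower number from compound 2 to compound 3 (0.88 log units; beyond the scatter) came with ((4-methylphenyl)carbonyl)oxy in place of (phenylsulfonyl)amino on a saturated ring carbon. The third step, a 4.5-fold lower number from compound 1 to compound 3 (0.65 log units; beyond the scatter), came with methyl in place of hydrogen on an aromatic carbon.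

Compound 4, `CC(=O)NC1CCC(CN2CCN(c3cc(=O)c4cc(C(F)(F)F)cc([N+](=O)[O-])c4s3)CC2)CC1`, is not yet measured. It differs from compound 2 by acetyl in place of phenylsulfonyl on an amine nitrogen. Within the data shown here, no measured step changes only the group on that amine nitrogen; the steps that move away from (phenylsulfonyl)amino replace the whole group and point downward. A modest drop from compound 2 is therefore expected, though the limit on compound 2 leaves the size uncertain. Compound 4 is expected to give about 1.2 h, with a range from 0.45 h to 3 h, an expected step of an at least 1.2-fold lower number from compound 2 to compound 4 (0.11 log units; that floor lies within the scatter).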

Compound 4, half-life: > 1.55 h
Compound 4 ended at the assay's limit (the forecaster's own chance of this, stated with the estimate: 35%); at least 1.2-fold (0.11 log units) between middle value and limit.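

The step between compound 2 and compound 4 cannot be read, because both values are limits of the assay: the limit of > 1.55 h in this assay, at which 2 of the 4 values shown sit.

Even so, replacing phenylsulfonyl with the smaller acetyl removes the aromatic ring from the amine nitrogen, and compound 4 still reaches that same limit, so this ring is not needed to reach it in this assay. The comparisons with the two compounds carrying an ester-type group on the saturated ring carbon differ: replacing ((4-methylphenyl)carbonyl)oxy with acetamido gives an at least 7.6-fold higher number from compound 3 to compound 4 (0.88 log units; beyond the scatter), whereas replacing benzoyloxy with acetamido gives an at least 1.7-fold higher number from compound 1 to compound 4 (0.23 log units; that floor lies within the scatter), so only the first of these steps shows a clear gain.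

From the compounds shown here alone, how far compound 2 and compound 4 each lie past the limit remains unknown, so these two compounds cannot be ranked against each other in this assay. Going by these compounds, it also remains open whether a free amine or a carboxylic acid on the same saturated ring carbon would reach this limit as well, or whether something other than the sulfonyl or acetyl group on that nitrogen would bring the number back down.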